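Extending the Amide Linker of Compound 1

The compounds below may be only part of what the source reports. "The series", "measured", "known", "first", "only" and "open" are said of these compounds alone.

Among the measured compounds shown here, compound 1 `Nc1ccccc1NC(=O)c1ccc(Cn2cnc3c(Nc4ccccc4)nc(Cl)nc32)cc1` gives 77.8% in a functional assay on NCI-H460 cells (Homo sapiens) for antiproliferative activity, read by CCK-8 assay, with a stated time of 72 h, tested at 8 uM (a lower number here means a weaker effect, a higher number a stronger effect of the compound at the concentration tested), the highest of the three numbers measured so far. Compound 3 `CN1CCN(c2nc(Cl)nc3c2ncn3Cc2ccc(C(=O)Nc3ccccc3N)cc2)CC1` gives 55.1%, and compound 2 `Nc1ccccc1NC(=O)c1ccc(Cn2cnc3c(Nc4ccc(-c5ccccn5)cc4)nc(Cl)nc32)cc1` gives 30.8%. Compound 4 `Nc1ccccc1NC(=O)/C=C/c1ccc(Cn2cnc3c(Nc4ccccc4)nc(Cl)nc32)cc1` has not yet been measured; it differs from compound 1 by 2-((2-aminophenyl)carbamoyl)ethenyl in place of (2-aminophenyl)carbamoyl on an aromatic carbon. The two measured steps, a number 47 percentage points lower from compound 1 to compound 2 (beyond the scatter) and a number 22.7 percentage points lower from compound 1 to compound 3 (beyond the scatter), both alter a different part of the shared core and so bear only loosely on this change: they show that the series can lose activity on substitution, but neither tests the linker itself. Compound 4 is therefore expected to stay close to compound 1, with an estimated step of a number 7.8 percentage points lower from compound 1 to compound 4 (within the scatter). The estimate for compound 4 in this assay is 70%, between 45% and 90%.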

Compound 4, a percentage reported as inhibition, at one concentration (the size of the read-out at that concentration, not a potency): 28.7%
Estimate against measurement, compound 4: 41.3 percentage points above; the whole stated range lies above it.
By their numbers in this assay, from the lowest: compounds 4 and 2 (each within the scatter of the next); then compound 3; then compound 1.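

Among the compounds shown here, the result shows that the site carrying the (2-aminophenyl)carbamoyl group, on an aromatic carbon para to a large group, is itself sensitive to change, which the earlier steps elsewhere on the shared core could not show. In this assay, placing 2-((2-aminophenyl)carbamoyl)ethenyl there gives a number 49.1 percentage points lower from compound 1 to compound 4 (beyond the scatter), so the added ethenyl unit alone costs much of the activity of compound 1. Nothing available bears on why the activity falls.

From the compounds shown here alone, whether a saturated ethyl chain in place of the ethenyl unit would keep this loss remains open. So does whether a hydroxamic acid in place of the 2-aminophenyl amide would behave differently on the ethenyl chain.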